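The compounds below may be only part of what the source reports. "The series", "measured", "known", "first", "only" and "open" are said of these compounds alone.

The series holds three measured compounds that share one core and differ only in the group carried on an amine nitrogen in a ring: compound 1 `CCCn1c(=O)[nH]c2nc(-c3ccc(S(=O)(=O)N4CCN(c5cccc(Br)c5)CC4)cc3)[nH]c2c1=O`, compound 2 `CCCn1c(=O)[nH]c2nc(-c3ccc(S(=O)(=O)N4CCN(c5ccc(Br)cc5)CC4)cc3)[nH]c2c1=O` and compound 3 `CCCn1c(=O)[nH]c2nc(-c3ccc(S(=O)(=O)N4CCN(c5ccccc5Cl)CC4)cc3)[nH]c2c1=O`. In an assay on CHO cells for displacement of a labelled ligand from adenosine receptor A1 (Homo sapiens), read by scintillation counting, with a stated time of 90 min, in the presence of a further agent that is not named here (on this read-out higher numbers stand for weaker inhibition and lower numbers for stronger inhibition), compound 1 gives only a limit of the assay, > 1000 nM. In this assay compound 2 likewise gives a limit, > 1000 nM. In this assay compound 3 also gives a limit, > 1000 nM, so compound 3 stands at the same limit as the other two and no number for it is known. The steps among the three are a step that the two limits leave unreadable from compound 1 to compound 2, a step that the two limits leave unreadable from compound 1 to compound 3 and a step that the two limits leave unreadable from compound 2 to compound 3; none of them can be sized because of the limit of > 1000 nM in this assay, at which 3 of the 3 values shown sit.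

Compound 4 `CCCn1c(=O)[nH]c2nc(-c3ccc(S(=O)(=O)N4CCN(c5ccccc5C)CC4)cc3)[nH]c2c1=O` is not yet measured. It differs from compound 3 by methyl in place of chloro on an aromatic carbon. Going by the values given here, every measured step concerns the group on the amine nitrogen in a ring, and none of them leaves the limit, so no step of readable size is available to anchor the exchange of chloro for methyl. The expectation for this assay is therefore a value that stays at or near the limit, with the step from compound 3 to compound 4 estimated as a step that the limit leaves unreadable from compound 3 to compound 4. For compound 4 the estimate in this assay is 3000 nM, within a range from 1000 nM to 10000 nM.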

Compound 4, inhibition constant: 419 nM
Estimate against measurement, compound 4: 7.2-fold (0.85 log units) above, outside the stated range (below it).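

In this assay, methyl on an aromatic carbon ortho to a large group gives the series its first step with a readable lower bound: an at least 2.3-fold lower number from compound 3 to compound 4 (0.37 log units; beyond the scatter) with methyl in place of chloro, a single heavy atom exchanged for another with no change in the hydrogen-bond donors or acceptors counted. The same holds against the two bromophenyl compounds, with an at least 2.3-fold lower number from compound 2 to compound 4 (0.37 log units; beyond the scatter) for 2-methylphenyl in place of 4-bromophenyl and an at least 2.3-fold lower number from compound 1 to compound 4 (0.37 log units; beyond the scatter) for 2-methylphenyl in place of 3-bromophenyl, so among the four compounds only compound 4 has left the limit. The steps among compound 1, compound 2 and compound 3 still cannot be read, and the three steps to compound 4 stay lower bounds rather than sizes because of where those values sit: the limit of > 1000 nM in this assay, at which 3 of the 4 values shown sit.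

Going by these compounds, how far compound 1, compound 2 and compound 3 actually lie from compound 4 stays open, since no number is known for any of the three. Also open, on these data alone, is whether an ethyl or methoxy group at this place would read like methyl, and whether methyl on another carbon of this ring would do the same.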